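Chloromethyl to iodomethyl exchange in the series

A few compounds are considered here, and "the series" means these few. Any claim that something is new, unique, unknown or untested is made for them only; others in the source may bear on it.

- compound 1 `CCOC[C@H]1O[C@@H](n2c(Cl)nc3cc(Cl)c(Cl)cc32)[C@H](OC(C)=O)[C@@H]1OC(C)=O` in a functional assay on HFF cells (Homo sapiens) for cytotoxicity (on this read-out lower numbers stand for stronger inhibition and higher numbers for weaker inhibition), gives 33000 nM
- compound 2 `CC(=O)OC1C(CCl)OC(n2c(Cl)nc3cc(Cl)c(Cl)cc32)C1OC(C)=O` in this assay gives 32000 nM

In this assay compound 2 and compound 1 lie within the scatter of each other. Compound 3 `CC(=O)OC1C(CI)OC(n2c(Cl)nc3cc(Cl)c(Cl)cc32)C1OC(C)=O` carries iodo in place of chloro on a saturated chain carbon bound to a saturated ring carbon. Among the compounds with values here, no measured pair covers this exchange, so no step beyond the scatter is expected in this assay. The estimated change is a 1.3-fold lower number from compound 2 to compound 3 (0.11 log units; within the scatter) and stays within the scatter. For compound 3 the expected value is 25000 nM (estimated range 8000 nM to 80000 nM).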

Compound 3, half-maximal inhibitory concentration: 32000 nM
The estimate for compound 3 lay 1.3-fold (0.11 log units) below the measured number; measured number inside the range.
By their numbers in this assay, from the lowest: compounds 2, 3 and 1 (each within the scatter of the next).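

In this assay, iodo in place of chloro on a saturated chain carbon bound to a saturated ring carbon gives no change at the digits printed from compound 2 to compound 3 (within the scatter). Within the data shown here, this is the first halogen exchange read at this position, and the read-out does not separate chloromethyl from iodomethyl. No measurement shown here bears on an explanation of this result. Still open, from the compounds shown here alone, is whether an amine, a carboxylic acid or a longer chain on this carbon would give a step beyond the scatter. Fluoro and bromo at this position also remain open.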